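The source may report more compounds than this note shows. Statements on the series, on what has been measured and on what is new or still open speak of the compounds shown alone.

Measured so far in a functional assay on HEK293 cells for agonist activity at G-protein coupled receptor 39 (Homo sapiens), read by scintillation proximity assay and inositol phosphate accumulation, with a stated time of 75 min; a lower number here means that less compound is needed, a higher number that more compound is needed for the effect:
compound 1 `Cc1nn(-c2ncnc3nc[nH]c23)c2c1C(OC1CCCC1)CC(=O)N2` gives 62 nM;
compound 2 `Cc1nn(-c2ncnc3nc[nH]c23)c2c1C(OCc1ccc(C(C)C)cc1)CC(=O)N2` gives 1690 nM;
compound 3 `Cc1nn(-c2ncnc3nc[nH]c23)c2c1C(C(=O)N(C)c1ccccc1)CC(=O)N2` gives 5220 nM.

Among these three, compound 2 holds the second highest number: it sits above compound 1 by a 27-fold higher number from compound 1 to compound 2 (1.44 log units; beyond the scatter) and below compound 3, which differs from it by a gap beyond the scatter. Compound 4 `Cc1nn(-c2ncnc3nc[nH]c23)c2c1C(OCc1cc(F)cc3c1OCOC3)CC(=O)N2` keeps the shared core and the benzylic ether of compound 2 but changes the aromatic part: a group of 11 heavy atoms (8 carbon, 2 oxygen, 1 fluorine; one six-membered non-aromatic ring with 2 hetero atoms, one six-membered aromatic ring of carbon only) in place of a group of 9 heavy atoms (9 carbon; one six-membered aromatic ring of carbon only), on a saturated chain carbon bound to an oxygen on a saturated carbon.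

Among the compounds with values here, two measured steps bear on this. The step from compound 1 to compound 2, a 27-fold higher number from compound 1 to compound 2 (1.44 log units; beyond the scatter), and the step from compound 1 to compound 3, an 84-fold higher number from compound 1 to compound 3 (1.93 log units; beyond the scatter), both show that moving away from the cyclopentyl ether raises the number strongly. Within the data shown here, neither step, however, compares one benzylic aromatic group with another, so the present change has no direct precedent; the effect of exchanging the substituents on the aromatic ring is unknown from these data. Compound 4 is therefore expected to stay close to compound 2, with a 1.1-fold lower number from compound 2 to compound 4 (0.05 log units; within the scatter) likely within the scatter, and its estimated value is 1500 nM (range 400 nM to 6000 nM).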

Compound 4, half-maximal effective concentration: 30 nM
Estimate against measurement, compound 4: 50-fold (1.70 log units) above; measured number outside the range, below it.
By their numbers in this assay, from the lowest: compound 4; then compound 1; then compound 2; then compound 3.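

In this assay, within the data shown here, this position on the saturated chain carbon bound to the ether oxygen proves highly sensitive to the aromatic group, a point the earlier steps could not show because none of them compared one such group with another. Keeping the benzylic ether and replacing 4-isopropylphenyl with the fluorine-bearing group containing a six-membered non-aromatic ring with 2 hetero atoms gives a 56-fold lower number from compound 2 to compound 4 (1.75 log units; beyond the scatter) in this assay, so a benzylic ether is not tied to a high number here. Nothing measured here explains this step.

The compounds shown leave open whether the fluorine, the non-aromatic ring or their combination accounts for the change, since all of these enter together. They also leave open how a plain phenyl, a 4-fluorophenyl or an aminomethyl-bearing phenyl group would behave at this place.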